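A few compounds are considered here, and "the series" means these few. Any claim that something is new, unique, unknown or untested is made for them only; others in the source may bear on it.

Compound 1 `CCC(=O)NC[C@@H]1CC1c1cccc2oc(CCCCc3ccccc3)cc12` and compound 2 `O=C(NC[C@@H]1CC1c1cccc2oc(CCCCc3ccccc3)cc12)C1CC1` share a core and differ only at the carbonyl. In an assay on NIH3T3 cells for binding affinity to melatonin receptor type 1A (Homo sapiens) (on this read-out lower numbers stand for stronger inhibition and higher numbers for weaker inhibition), compound 1 gives 2.1 nM, the lowest of the two numbers shown, and compound 2 gives 16 nM. The step of a 7.6-fold higher number from compound 1 to compound 2 (0.88 log units; beyond the scatter) shows that the amide end of the side chain is not indifferent to change.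

Compound 3 `CC(=O)N[C@H]1CCN(c2cccc3oc(CCCCc4ccccc4)cc23)C1` differs from compound 1 in a different way: 3-acetamidopyrrolidin-1-yl in place of 2-((propanoylamino)methyl)cyclopropyl on an aromatic carbon. Among the compounds with values here, no measured step covers this exchange; the only step recorded, a 7.6-fold higher number from compound 1 to compound 2 (0.88 log units; beyond the scatter), touches the carbonyl substituent and not the ring that links the amide to the core, so it bears on the present change only as a sign that this region is sensitive. Because of a 7.6-fold higher number from compound 1 to compound 2 (0.88 log units; beyond the scatter) a change in this part of the molecule is expected to cost affinity rather than gain it, and for compound 3 a step of a 4.8-fold higher number from compound 1 to compound 3 (0.68 log units; beyond the scatter) is estimated. Compound 3 is therefore expected to give about 10 nM in this assay, with a range from 1.5 nM to 80 nM.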

Compound 3, inhibition constant: 22 nM
Compound 3: middle estimate off by 2.2-fold (0.34 log units), on the low side; the range from low to high includes it.
By their numbers in this assay, from the lowest: compound 1; then compounds 2 and 3 (each within the scatter of the next).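

In this assay, replacing 2-((propanoylamino)methyl)cyclopropyl with 3-acetamidopyrrolidin-1-yl gives a 10-fold higher number from compound 1 to compound 3 (1.02 log units; beyond the scatter), so sensitivity in this part of the molecule is not confined to the carbonyl substituent, the only place changed in a 7.6-fold higher number from compound 1 to compound 2 (0.88 log units; beyond the scatter). The number of heavy atoms does not separate the two groups, as each has 9; they differ in the ring, a three-membered carbon ring against a five-membered ring with 1 hetero atom, and in the acyl end of the amide. No measurement bearing on the cause of this step is at hand.

The exchange alters the ring, the atom attached to the aromatic carbon and the acyl end at once, so the compounds shown do not tell how much of the step belongs to each. A pyrrolidine carrying a propanamide instead of the acetamide would separate the acyl end from the ring, and an azetidine, a piperidine or an open ethyl chain in that place would show how affinity follows the linker.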